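Notes on the step from compound 2 to compound 3

The compounds below may be only part of what the source reports. "The series", "measured", "known", "first", "only" and "open" are said of these compounds alone.

Values measured so far in an ADME assay on L02 cells (Homo sapiens) for cytotoxicity, read by MTT assay, with a stated time of 24 h (a lower number here means a stronger inhibitor, a higher number a weaker inhibitor), are these:
- compound 1 `O=C1/C(=C/c2cccnc2)CNC/C1=C\c1ccccc1C(F)(F)F` gives 11300 nM
- compound 2 `O=C1/C(=C/c2ccncc2)CNC/C1=C\c1ccccc1C(F)(F)F` gives 13400 nM

Compound 2 stands within the scatter of compound 1, so no order can be drawn between the two. Among the compounds with values here, the only measured step is a 1.2-fold higher number from compound 1 to compound 2 (0.07 log units; within the scatter) for pyridin-4-yl in place of pyridin-3-yl. That step lies at a different place from the change now in question, so it bears on it only indirectly.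

Compound 3 `O=C1/C(=C/c2ccncc2)CN(S(=O)(=O)c2ccc(Br)cc2)C/C1=C\c1ccccc1C(F)(F)F` has (4-bromophenyl)sulfonyl in place of hydrogen on an amine nitrogen in a ring, counted as (4-bromophenyl)sulfonyl in place of hydrogen on an amine nitrogen in a ring and not yet tested in any measured compound. The data therefore give neither a size nor a direction for this change, and no step beyond the scatter can be argued from them. In this assay the expected change is a 1.3-fold lower number from compound 2 to compound 3 (0.13 log units; within the scatter) as a working estimate with no firm direction behind it. The range is kept wide for lack of any measured precedent. Compound 3 is expected at 10000 nM within a range of 3000 nM to 35000 nM on this estimate.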

Compound 3, half-maximal inhibitory concentration: 12600 nM
Estimate against measurement, compound 3: 1.3-fold (0.10 log units) below; the measured number falls inside the stated range.
By their numbers in this assay, from the lowest: compounds 1, 3 and 2 (each within the scatter of the next).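

In this assay the amine nitrogen in the ring carries something other than hydrogen for the first time among these compounds, and the step is a 1.1-fold lower number from compound 2 to compound 3 (0.03 log units; within the scatter). The earlier compounds shown here differed only in the pyridine, so they said nothing about this nitrogen; this pair shows that (4-bromophenyl)sulfonyl, with its 10 heavy atoms and its six-membered aromatic ring of carbon only, can stand in place of hydrogen there with no readable difference in this read-out. No measured information on the compounds bears on this result, so the data offer no explanation for it.

The compounds shown leave open whether this holds for the sulfonyl link in general or for other kinds of group on the same nitrogen, such as an acetyl group or a benzyl group, which would separate the link from the aromatic ring. They also leave open what part the bromine plays, a question that a plain phenylsulfonyl group on that nitrogen would address directly.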